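A few compounds are considered here, and "the series" means these few. Any claim that something is new, unique, unknown or untested is made for them only; others in the source may bear on it.

Compound 3 `CC(C)c1onc(-c2c(Cl)cccc2Cl)c1COc1ccc(N(C)Cc2ccc(C(=O)NS(C)(=O)=O)cc2)c(C(F)(F)F)n1` gives 40 nM in an assay on isolated protein for agonist activity at Bile acid receptor (Homo sapiens), read by FRET (on this read-out lower numbers stand for an effect already at smaller amounts and higher numbers for an effect only at larger amounts of compound), which places it second highest of the three numbers measured: compound 2 `CC(C)c1onc(-c2c(Cl)cccc2Cl)c1COc1ccc(N(C)Cc2ccc(CCC(=O)O)cc2)c(C(F)(F)F)n1` gives 17 nM, and compound 1 `CC(C)c1onc(-c2c(Cl)cccc2Cl)c1COc1ccc(N(C)C(=O)c2ccc(C(=O)O)cc2)c(C(F)(F)F)n1` gives 235 nM. Compound 4 `CC(C)c1onc(-c2c(Cl)cccc2Cl)c1COc1ccc(N(C)Cc2ccc(OCCO)cc2)c(C(F)(F)F)n1` differs from compound 3 in one place: 2-hydroxyethoxy in place of (methylsulfonyl)carbamoyl on an aromatic carbon.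

Among the measured compounds shown here, two measured steps bear on this change, both at the same end of the shared core. The step of a 14-fold lower number from compound 1 to compound 2 (1.14 log units; beyond the scatter) was large, and the step of a 2.4-fold higher number from compound 2 to compound 3 (0.37 log units; beyond the scatter) was modest. For the measured compounds named here, both compound 2 and compound 3 carry either a 2-carboxyethyl or a (methylsulfonyl)carbamoyl group on that aromatic carbon; compound 4 carries neither, and no measured step shows what a 2-hydroxyethoxy group does there. The swap between compound 2 and compound 3 cost only a modest amount, so a modest step in the same direction is expected for compound 4, a 2.8-fold higher number from compound 3 to compound 4 (0.44 log units; beyond the scatter). Compound 4 is therefore estimated at 110 nM, with a range from 30 nM to 450 nM.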

Compound 4, half-maximal effective concentration: 164 nM
Compound 4: the middle estimate sits 1.5-fold (0.17 log units) below what was measured, and the stated range covers the measured number.
By their numbers in this assay, from the lowest: compound 2; then compound 3; then compounds 4 and 1 (each within the scatter of the next).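

The aromatic carbon para to the large group responds more strongly than the earlier swap suggested: the step of a 4.1-fold higher number from compound 3 to compound 4 (0.61 log units; beyond the scatter) is larger than the step of a 2.4-fold higher number from compound 2 to compound 3 (0.37 log units; beyond the scatter), and the step of a 9.6-fold higher number from compound 2 to compound 4 (0.98 log units; beyond the scatter) is larger still. The 2-hydroxyethoxy group therefore does not match either earlier group at this position, even though it has a hydrogen-bond donor and no net charge, like the (methylsulfonyl)carbamoyl group it replaces. The step of a 1.4-fold lower number from compound 1 to compound 4 (0.16 log units; within the scatter) leaves these two compounds indistinguishable, so a benzyl link on the nitrogen does not by itself give a low number. No available evidence explains these differences. From the compounds shown here alone, it remains open how a 2-aminoethoxy group or a carboxymethoxy group would read at this carbon, and whether a longer chain such as 3-hydroxypropoxy would differ from 2-hydroxyethoxy.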